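Oleoyl chain on the free thioglycoside: expected cytotoxicity

The source may hold more compounds than are shown below. What is called first, only, known or untested is meant among the compounds shown, and "the series" means these compounds.

Two compounds of this series have numbers in a functional assay on MDA-MB-231 cells (Homo sapiens) for cytotoxicity, read by MTT assay, with a stated time of 24 h; on this read-out lower numbers stand for stronger inhibition and higher numbers for weaker inhibition. Compound 1 `CCCCCCCC/C=C\CCCCCCCC(=O)Nc1nnc(S[C@@H]2O[C@H](COC(C)=O)[C@H](OC(C)=O)[C@H](OC(C)=O)[C@H]2OC(C)=O)s1` carries the unsaturated long acyl chain on the amide and the tetra-acetylated sugar; in this assay compound 1 gives 23600 nM. Compound 2 `CCCCCCCCCC(=O)Nc1nnc(S[C@@H]2O[C@H](CO)[C@H](O)[C@H](O)[C@H]2O)s1` carries the shorter saturated decanoyl amide on the free sugar; in this assay compound 2 gives 53100 nM, the higher of the two numbers, beyond the scatter away from compound 1. Among the measured compounds shown here, no pair of measured compounds differs in a single place, so the two values cannot be split between the acyl chain and the sugar acetylation.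

Compound 3 `CCCCCCCC/C=C\CCCCCCCC(=O)Nc1nnc(S[C@@H]2O[C@H](CO)[C@H](O)[C@H](O)[C@H]2O)s1` keeps the free sugar of compound 2 and takes the acyl chain of compound 1. The change is dec-1-en-1-yl in place of ethyl on a saturated chain carbon, seven bonds along the chain from a carbonyl carbon. For the measured compounds named here, with no measured single step to lean on, only a modest move toward a lower number is expected for compound 3, of about the size a 1.5-fold lower number from compound 2 to compound 3 (0.18 log units; within the scatter), which may not exceed the scatter. For compound 3 in this assay the estimate is 35000 nM, with a plausible range from 15000 nM to 80000 nM.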

Compound 3, half-maximal inhibitory concentration: 43600 nM
For compound 3 the middle estimate is 1.2-fold (0.10 log units) below the measured one; the measured number falls inside the stated range.
By their numbers in this assay, from the lowest: compounds 1, 3 and 2 (each within the scatter of the next, the first and the last beyond it).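

In this assay, among the compounds shown here, the free-sugar pair gives the first single-place comparison: dec-1-en-1-yl in place of ethyl on a saturated chain carbon, seven bonds along the chain from a carbonyl carbon, gives a 1.2-fold lower number from compound 2 to compound 3 (0.09 log units; within the scatter) on this sugar form. At this position, the much longer chain with its one double bond therefore does not separate the two compounds on this read-out, which the earlier pair could not show because it differed in both the chain and the sugar acetylation. No measured property bears on this result, so the flat step remains without an explanation.

Still open, on these data alone, is whether chain length and the double bond each leave this read-out unchanged, or whether their separate contributions merely cancel; a saturated octadecanoyl chain would address that question, and a chain carrying an amine or a carboxylic acid would test a different kind of change at the same place. The contribution of the acetyl groups on the sugar also remains open, as no single-place step among the compounds shown isolates it.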